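One Enantiomer Separated From an Unresolved Pyrrolidine Amine

The source may report more compounds than this note shows. Statements on the series, on what has been measured and on what is new or still open speak of the compounds shown alone.

Measured compounds:
compound 1 `Cn1cc(-c2n[nH]c3ccc(-c4ccccc4)cc23)cn1`: 620 nM
compound 2 `CNC1CCN(c2ccc3[nH]nc(-c4cnn(C)c4)c3c2)C1`: 432000 nM
compound 3 `Cn1cc(-c2n[nH]c3ccc(NC4CCNC4)cc23)cn1`: 132000 nM

In an assay on isolated protein for inhibition of tyrosine-protein kinase receptor UFO (Homo sapiens), with a stated time of 1.5 h (a higher number here means a weaker inhibitor, a lower number a stronger inhibitor), compound 3 gives the second highest number of the three. Its nearest neighbour is compound 2, reached by a 3.3-fold lower number from compound 2 to compound 3 (0.51 log units; beyond the scatter) read backwards; its furthest neighbour is separated by a 210-fold higher number from compound 1 to compound 3 (2.33 log units; beyond the scatter).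

Compound 4 `Cn1cc(-c2n[nH]c3ccc(N[C@H]4CCNC4)cc23)cn1` differs from compound 3 only as follows: the two compounds have the same atoms and bonds; at least one stereo element is drawn with a configuration in one of them and without one in the other: 1 of 1 stereo elements differ; a stereocentre at a saturated ring carbon is drawn without a configuration in compound 3 and S in compound 4. For the measured compounds named here, no measured step bears on this change: the steps of a 700-fold higher number from compound 1 to compound 2 (2.84 log units; beyond the scatter) and a 210-fold higher number from compound 1 to compound 3 (2.33 log units; beyond the scatter) exchange whole groups, and a 3.3-fold lower number from compound 2 to compound 3 (0.51 log units; beyond the scatter) exchanges one amine-bearing ring for another, none touching a stereocentre. Because compound 3 gives 132000 nM and is an unresolved mixture containing compound 4, compound 4 is expected to be near it, with a 1.3-fold lower number from compound 3 to compound 4 (0.12 log units; within the scatter), though a single enantiomer could be either somewhat stronger or weaker. The estimate for compound 4 is 100000 nM, within 35000 nM to 300000 nM.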

Compound 4, half-maximal inhibitory concentration: 239000 nM
The estimate for compound 4 lay 2.4-fold (0.38 log units) below the measured number; measured number inside the range.
By their numbers in this assay, from the lowest: compound 1; then compounds 3, 4 and 2 (each within the scatter of the next, the first and the last beyond it).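

In this assay, the two forms of the (pyrrolidin-3-yl)amino compound differ in one respect only: the fact that one of compounds 3 and 4 is drawn with a defined configuration and the other without, at the place where they differ. Defining the stereocentre as S gives a 1.8-fold higher number from compound 3 to compound 4 (0.26 log units; within the scatter), and the single enantiomer also shows a 1.8-fold lower number from compound 2 to compound 4 (0.26 log units; within the scatter), so the gap seen between compound 2 and compound 3 does not hold up for compound 4. The distance from the phenyl group remains large, at a 390-fold higher number from compound 1 to compound 4 (2.59 log units; beyond the scatter).

On these data alone, what the R enantiomer would give stays open. So does whether a different group at this place, such as a carboxylic acid or a pyridine ring, would come closer to phenyl.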